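The source may report more compounds than this note shows. Statements on the series, on what has been measured and on what is new or still open speak of the compounds shown alone.

In a functional assay on SW480 cells (Homo sapiens) for cytotoxicity, read by sulforhodamine B assay, with a stated time of 48 h (on this read-out lower numbers stand for stronger inhibition and higher numbers for weaker inhibition), compound 1 `COc1ccc(/C=C/C(=O)c2cccc(-c3ccc(F)cc3)c2)cc1` gives 8350 nM and compound 2 `COc1ccc(/C=C/C(=O)c2ccc(N)c(-c3ccc(F)cc3)c2)cc1` gives 7230 nM. For the measured compounds named here, these are the only two numbers so far and they lie within the usual scatter of each other, so compound 1 cannot yet be placed clearly on either side of compound 2. Compound 3 `COc1ccc(/C=C/C(=O)c2cccc(-c3ccc(F)cc3)c2)cc1OC` keeps the core of compound 1 and makes one change: methoxy in place of hydrogen on an aromatic carbon, ortho to a methoxy group. Going by the values given here, the one measured step that can guide us is a different change, amino in place of hydrogen on an aromatic carbon, and it stayed small: a 1.2-fold lower number from compound 1 to compound 2 (0.06 log units; within the scatter). This single step offers only weak guidance, so the change expected in this assay stays within the scatter, with no direction favoured. For compound 3 the expected value is 7000 nM, with an estimated range of 2800 nM to 17000 nM. The expected step is a 1.2-fold lower number from compound 1 to compound 3 (0.08 log units; within the scatter).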

Compound 3, half-maximal inhibitory concentration: 6490 nM
Estimate against measurement, compound 3: 1.1-fold (0.03 log units) above, within the range that was stated.
By their numbers in this assay, from the lowest: compounds 3, 2 and 1 (each within the scatter of the next).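

In this assay, a methoxy group on an aromatic carbon, ortho to the methoxy group already present and meta to a large group, gives a 1.3-fold lower number from compound 1 to compound 3 (0.11 log units; within the scatter) for the step. This position can therefore carry the added methoxy, with its 2 heavy atoms and 1 hydrogen-bond acceptor, without a reading that can be told apart from that of compound 1. Nothing measured here accounts for this result.

Still open, as far as these compounds go, is whether a different group at this same position, such as a hydroxyl, an amine or a longer ethoxy chain, would shift the number beyond the scatter. Also open, from the compounds shown here alone, is how the methoxy group would behave alongside the amino group of compound 2 on the shared core.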